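The source may hold more compounds than are shown below. What is called first, only, known or untested is meant among the compounds shown, and "the series" means these compounds.

Compound 1 `CCNC(=O)[C@H]1O[C@@H](n2cnc3c(NNC(=O)c4ccccc4)ncnc32)[C@H](O)[C@@H]1O` opens the small series. In an assay on CHO cells for displacement of a labelled ligand from adenosine receptor A1 (Homo sapiens) (a lower number here means a stronger inhibitor, a higher number a weaker inhibitor), compound 1 gives > 5000 nM, which is a limit of the assay and not a number. Compound 2 `CCNC(=O)[C@H]1O[C@@H](n2cnc3c(NNC(=O)c4ccc(Cl)cc4)ncnc32)[C@H](O)[C@@H]1O` carries chloro in place of hydrogen on an aromatic carbon. In this assay compound 2 gives > 5000 nM, again a limit of the assay and not a number. The step that the two limits leave unreadable from compound 1 to compound 2 cannot be read, since (the limit of > 5000 nM in this assay, at which 2 of the 2 values shown sit). Compound 3 `CCNC(=O)[C@H]1O[C@@H](n2cnc3c(NNC(=O)c4cccnc4)ncnc32)[C@H](O)[C@@H]1O` differs from compound 2 by pyridin-3-yl in place of 4-chlorophenyl on a carbonyl carbon. No measured step bears on this change: the single step shown is unreadable, and compound 2 itself stands only at a limit. Compound 3 is expected to remain at or near that same limit, with an expected step that the limit leaves unreadable from compound 2 to compound 3 and no direction beyond the scatter. The estimate for compound 3 in this assay is 8000 nM, with a range from 2000 nM to 30000 nM.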

Compound 3, inhibition constant: > 5000 nM
Compound 3: a limit, no number; the forecaster's own chance of this, stated with the estimate: 80%; the middle value does not contradict the limit.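

For the compounds shown here, compound 3 also stands only at a limit of the assay, so no step among compound 1, compound 2 and compound 3 can be read: the limit of > 5000 nM in this assay, at which 3 of the 3 values shown sit. The compounds shown leave open where any of the three truly stands in this assay, and whether phenyl, 4-chlorophenyl or pyridin-3-yl makes any difference there.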